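One More Methoxy on a Prenylated Aromatic Ring

This account rests on a few compounds, and the source may have more. Where it says the series, first, only, none or still open, it means among the compounds named here.

Of the compounds shown here, three have been measured so far in an assay on cells for inhibition of Amine oxidase [flavin-containing] B (Homo sapiens), read by fluorescence, with stated times of 10 min and 20 min, tested at 25 uM; a higher number here means more inhibition at the concentration tested (going by the name of the read-out), a lower number less inhibition. Compound 1, `CC(C)=CCc1c(C)cc(O)c(O)c1O`, gives 32.7% in this assay. Compound 2, `COc1c(C)c(CC=C(C)C)c(OC)c(OC)c1OC`, gives 7.2%, and compound 3, `COc1cc(C)c(CC=C(C)C)c(OC)c1`, gives 5.4%. Compound 3 thus stands lowest of the three numbers, but its nearest neighbour, compound 2, lies within the scatter of it, so the two cannot be ordered; only compound 1 lies beyond the scatter above compound 3.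

Compound 4, `COc1cc(C)c(CC=C(C)C)c(OC)c1OC`, differs from compound 3 in a single place: methoxy in place of hydrogen on an aromatic carbon. The incoming group sits on an aromatic carbon of the six-membered aromatic ring of carbon only, ortho to two methoxy groups, meta to the 3-methylbut-2-en-1-yl group and para to the methyl group.

For the measured compounds named here, no pair of measured compounds shows this exact change, so the expectation rests on the neighbours. Compound 2 gives 7.2% and compound 3 gives 5.4%, two small numbers within the scatter of each other. The step of a number 0.6 percentage points higher from compound 3 to compound 4 (within the scatter) is therefore expected to be small and in no clear direction, not beyond the scatter. Compound 4 is estimated at 6%, with a range from 0% to 17%.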

Compound 4, a percentage reported as inhibition, at one concentration (the size of the read-out at that concentration, not a potency): 18.6%
Compound 4: middle estimate off by 12.6 percentage points, on the low side, and the stated range ends below it.
By their numbers in this assay, from the lowest: compounds 3 and 2 (each within the scatter of the next); then compound 4; then compound 1.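

In this assay the methoxy group on the aromatic carbon ortho to two methoxy groups, meta to the 3-methylbut-2-en-1-yl group and para to the methyl group proves to matter, with a number 13.2 percentage points higher from compound 3 to compound 4 (beyond the scatter) as the change from hydrogen to methoxy there. The second step, a number 11.4 percentage points higher from compound 2 to compound 4 (beyond the scatter), comes from hydrogen in place of methoxy on a different aromatic carbon, so among these three compounds a methoxy group does not count the same on every ring carbon: at one carbon its arrival goes with a higher number, and at the other its removal does. No measurement available here accounts for this difference between the two carbons.

Compound 1 differs from the others in more than one place, so the gaps to it cannot be read as steps, and what its hydroxyl groups contribute stays unresolved. Also open, going by these compounds, is whether a hydroxyl, an ethoxy group or an amine on the carbon that carries the new methoxy group in compound 4 would give a higher or a lower number than methoxy does.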